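Half-life notes on the step from compound 3 to compound 4

The compounds below may be only part of what the source reports. "The series", "measured", "known", "first", "only" and "open" are said of these compounds alone.

Measured so far in an in vitro ADME assay on microsomes from liver (Homo sapiens) for metabolic stability, tested at 5 uM; on this read-out lower numbers stand for a shorter-lived compound and higher numbers for a longer-lived compound:
- compound 1 `CC(C)CCn1nc(-c2cccs2)c(O)c(C2=NS(=O)(=O)c3cc(O)ccc3N2)c1=O`: 0.0933 h
- compound 2 `CC(C)CCn1nc(-c2cccs2)c(O)c(C2=NS(=O)(=O)c3cc(OCC(N)=O)ccc3N2)c1=O`: 0.383 h
- compound 3 `CC(C)CCn1nc(-c2cccs2)c(O)c(C2=NS(=O)(=O)c3cc(OCC(=O)NO)ccc3N2)c1=O`: > 1 h

Compound 3 sits at the limit of > 1 h in this assay, at which 1 of the 3 values shown sits, so for compound 3 only a limit and no number is known. The step to compound 4 `CC(C)CCn1nc(-c2cccs2)c(O)c(C2=NS(=O)(=O)c3cc(NC(=O)C4CC4)ccc3N2)c1=O` is (cyclopropylcarbonyl)amino in place of (hydroxycarbamoyl)methoxy on an aromatic carbon. Among the compounds with values here, none of the measured steps makes such a change; all of them build on the oxygen of compound 1: a 4.1-fold higher number from compound 1 to compound 2 (0.61 log units; beyond the scatter), an at least 10-fold higher number from compound 1 to compound 3 (1.03 log units; beyond the scatter) and an at least 2.6-fold higher number from compound 2 to compound 3 (0.41 log units; beyond the scatter). Each addition on that oxygen raised the half-life, and compound 4 removes both that oxygen and the group present in compound 3, so a lower number is expected, in this assay given as an at least 2.0-fold lower number from compound 3 to compound 4 (0.30 log units; that floor lies within the scatter). Compound 4 is therefore estimated at 0.5 h, with a range from 0.15 h to 1.5 h.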

Compound 4, half-life: 0.0833 h
The estimate for compound 4 lay 6.0-fold (0.78 log units) above the measured number; the whole stated range lies above it.
By their numbers in this assay, from the lowest: compounds 4 and 1 (each within the scatter of the next); then compound 2. At a limit, above all of these: compound 3.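

In this assay, (cyclopropylcarbonyl)amino in place of hydroxy on this aromatic carbon leaves the half-life within the scatter: a 1.1-fold lower number from compound 1 to compound 4 (0.05 log units; within the scatter). A group of the same heavy-atom count as (hydroxycarbamoyl)methoxy therefore does not carry the longer half-life, and the oxygen-linked groups stand apart, with a 4.6-fold lower number from compound 2 to compound 4 (0.66 log units; beyond the scatter) and an at least 12-fold lower number from compound 3 to compound 4 (1.07 log units; beyond the scatter). The second of these steps rests on a limit for compound 3: the limit of > 1 h in this assay, at which 1 of the 4 values shown sits.

On these data alone, it remains open whether the oxygen link or the chain end goes with the longer half-life. A carboxylic acid at the chain end, or a carbamoylmethyl chain joined through an amine nitrogen, would bear on that.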